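This account rests on a few compounds, and the source may have more. Where it says the series, first, only, none or still open, it means among the compounds named here.

In a functional assay on NCI-H1650 cells (Homo sapiens) for cytotoxicity, read by MTT assay, with a stated time of 72 h (on this read-out lower numbers stand for stronger inhibition and higher numbers for weaker inhibition), compound 1 `CCN1C/C(=C\c2cc(OC)c(OC)c(OC)c2)C(=O)/C(=C/c2cc(OC)c(OC)c(OC)c2)C1` gives 8200 nM and compound 2 `CCN1C/C(=C\c2ccc(OC)c(OC)c2)C(=O)/C(=C/c2ccc(OC)c(OC)c2)C1` gives 12000 nM. Among the measured compounds shown here, these two numbers lie within the usual scatter of each other, so compound 1 cannot be separated from the only other measured compound. Compound 3 `COc1cc(/C=C2\CN(C(=O)c3ccccc3F)C/C(=C\c3cc(OC)c(OC)c(OC)c3)C2=O)cc(OC)c1OC` keeps the core of compound 1 and changes one group: (2-fluorophenyl)carbonyl in place of ethyl on an amine nitrogen in a ring, with (2-fluorophenyl)carbonyl in place of ethyl on an amine nitrogen in a ring. For the measured compounds named here, no measured pair shows this change, so the expectation is uncertain. In this assay the estimated change is a 4.1-fold lower number from compound 1 to compound 3 (0.61 log units; beyond the scatter), a moderate move toward stronger inhibition, beyond the scatter. The estimate for compound 3 is 2000 nM, with a range from 400 nM to 9000 nM.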

Compound 3, half-maximal inhibitory concentration: 1900 nM
For compound 3 the middle estimate is 1.1-fold (0.02 log units) above the measured one; measured number inside the range.
By their numbers in this assay, from the lowest: compound 3; then compounds 1 and 2 (each within the scatter of the next).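

In this assay, among the compounds shown here, the earlier compounds both carry ethyl on the amine nitrogen in the ring, so they say nothing about this position. Putting (2-fluorophenyl)carbonyl there gives a 4.3-fold lower number from compound 1 to compound 3 (0.64 log units; beyond the scatter) as the result, which shows that this nitrogen tolerates a larger group with an added aromatic ring and that inhibition becomes stronger. No available evidence explains why this change has this effect.
Still open, as far as these compounds go, is which part of the new group matters, the carbonyl, the ring or the fluorine. Phenylcarbonyl without fluorine, or a simple longer chain such as butyl, could help separate these parts.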